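The source may report more compounds than this note shows. Statements on the series, on what has been measured and on what is new or still open speak of the compounds shown alone.

Compound 1 `CC(=O)N1N=C(Nc2nc3ccc([N+](=O)[O-])cc3s2)CC1c1ccc(O)cc1`: 162 umol/kg
Compound 2 `CC(=O)N1N=C(Nc2nc3ccc(C)cc3s2)CC1c1ccc(Cl)cc1`: 25.5 umol/kg

Within the data shown here, in a functional assay on the whole organism (Hindlimb, strain albino) with Mus musculus as the target, in the maximal electroshock model, with a stated time of 0.5 h (on this read-out lower numbers stand for an effect already at smaller amounts and higher numbers for an effect only at larger amounts of compound), compound 2 gives 25.5 umol/kg, the lower of the two numbers so far. Compound 1 stands at 162 umol/kg, and the gap between them lies beyond the usual scatter. The two compounds differ in more than one place, so their gap cannot be tied to any single change.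

The next compound, compound 3 `CC(=O)N1N=C(Nc2nc3ccc([N+](=O)[O-])cc3s2)CC1c1ccc(Cl)cc1`, keeps the structure of compound 2 except for one change: nitro in place of methyl on an aromatic carbon. Among the measured compounds shown here, no measured pair shows this change alone, so the expectation rests on thin evidence. Compound 1 also carries nitro and reads 162 umol/kg, which points towards a higher number, but it differs from compound 2 elsewhere as well. Only a modest move is therefore expected, in the direction of larger amounts, and the estimated step is a 2.4-fold higher number from compound 2 to compound 3 (0.37 log units; beyond the scatter). For compound 3 the expected value is 60 umol/kg, with an estimated range of 20 umol/kg to 150 umol/kg.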

Compound 3, dose for half-maximal effect: 132 umol/kg
Estimate against measurement, compound 3: 2.2-fold (0.34 log units) below, and the stated range covers the measured number.
By their numbers in this assay, from the lowest: compound 2; then compounds 3 and 1 (each within the scatter of the next).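

In this assay, nitro in place of methyl on an aromatic carbon, with the rest of the structure unchanged, gives a 5.2-fold higher number from compound 2 to compound 3 (0.71 log units; beyond the scatter), so this single change at this place is enough to move the number beyond the scatter, which the earlier pair of compounds, differing in more than one place, could not show. With the nitro group kept, chloro in place of hydroxy on an aromatic carbon gives a 1.2-fold lower number from compound 1 to compound 3 (0.09 log units; within the scatter), so that second exchange shows no separation in this assay, at least while nitro is present. No measurement at hand speaks to why the nitro step has this size.

From the compounds shown here alone, only methyl and nitro have been seen at this place on the six-membered aromatic ring, so it remains open how an amine, a methoxy group or a fluoro group would read there, and whether the number depends on the particular group or follows some wider trend. It is also open whether chloro and hydroxy would still read alike with methyl in place of nitro, since the compounds shown test that exchange only alongside nitro.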